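Nitro for Dimethylamino on the Aryl Thiosemicarbazone

The source may report more compounds than this note shows. Statements on the series, on what has been measured and on what is new or still open speak of the compounds shown alone.

In a functional assay on PCO3 cells (Homo sapiens) for cytotoxicity, read by sulforhodamine B assay (a higher number here means a weaker inhibitor of growth, a lower number a stronger inhibitor of growth), compound 1 `CC1=CC[C@@H]([C@@](C)(O)CCCC(C)(C)NC(=S)N/N=C\c2ccccc2)CC1` gives 36200 nM. Compound 2 `COc1ccc(/C=N\NC(=S)NC(C)(C)CCC[C@](C)(O)[C@@H]2CC=C(C)CC2)cc1` gives 76100 nM in this assay. For compound 3 `CC1=CC[C@@H]([C@@](C)(O)CCCC(C)(C)NC(=S)N/N=C\c2ccc(N(C)C)cc2)CC1` this assay reports only a limit, > 100000 nM, so compound 3 stands at the weak end of the numbers shown. Compound 4 `CC1=CC[C@@H]([C@@](C)(O)CCCC(C)(C)NC(=S)N/N=C\c2ccc([N+](=O)[O-])cc2)CC1` differs from compound 3 by nitro in place of dimethylamino on an aromatic carbon. Among the measured compounds shown here, no measured step exchanges these two groups; the nearest are a 2.1-fold higher number from compound 1 to compound 2 (0.32 log units; beyond the scatter) and an at least 2.7-fold higher number from compound 1 to compound 3 (0.44 log units; beyond the scatter), both raising the number, while an at least 1.3-fold higher number from compound 2 to compound 3 (0.11 log units; that floor lies within the scatter). Because compound 3 sits at the limit of > 100000 nM in this assay, at which 1 of the 3 values shown sits, only a downward step could register as a number. Compound 4 is expected at 90000 nM, between 40000 nM and 200000 nM. For compound 4 the estimated step is an at least 1.1-fold lower number from compound 3 to compound 4 (0.04 log units; that floor lies within the scatter).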

Compound 4, concentration for total growth inhibition: > 100000 nM
Compound 4: no number, only a limit; the forecaster's own chance of this, stated with the estimate: 45%; middle value at least 1.1-fold (0.04 log units) from the limit.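

In this assay, nitro on the aromatic carbon para to a large group gives an at least 2.7-fold higher number from compound 1 to compound 4 (0.44 log units; beyond the scatter), and it joins methoxy and dimethylamino in raising the number over hydrogen at this position, with no compound shown going against that. Against methoxy the change gives an at least 1.3-fold higher number from compound 2 to compound 4 (0.11 log units; that floor lies within the scatter), and no order between those two groups can be claimed. The step from dimethylamino to nitro cannot be read, as compound 3 and compound 4 both carry only a limit: the limit of > 100000 nM in this assay, at which 2 of the 4 values shown sit.

On these data alone, whether a small group such as fluorine or methyl, or a carboxylic acid, at this position would give a lower number than compound 1 stays open. Also open, as far as these compounds go, is whether any change here can give a readable number at all.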